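This account rests on a few compounds, and the source may have more. Where it says the series, first, only, none or still open, it means among the compounds named here.

Measured compounds in a functional assay on HL-60 cells (Homo sapiens) for antiproliferative activity, with a stated time of 72 h; on this read-out higher numbers stand for weaker inhibition and lower numbers for stronger inhibition:
- compound 1 `OC[C@H]1O[C@@H](n2cnc3c(NCc4cccc(F)c4)ncnc32)[C@H](O)[C@@H]1O` gives 920 nM
- compound 2 `COc1cc(CNc2ncnc3c2ncn3[C@@H]2O[C@H](CO)[C@@H](O)[C@H]2O)cc(OC)c1` gives 20200 nM
- compound 3 `OC[C@H]1O[C@@H](n2cnc3c(NCc4ccc(F)c(F)c4F)ncnc32)[C@H](O)[C@@H]1O` gives 13000 nM

Compound 1 has the lowest number of the three; the next is compound 3, and compound 2 is furthest. The two steps away from compound 1 are both large: a 22-fold higher number from compound 1 to compound 2 (1.34 log units; beyond the scatter) and a 14-fold higher number from compound 1 to compound 3 (1.15 log units; beyond the scatter). Between the two weaker compounds the difference is small, a 1.6-fold lower number from compound 2 to compound 3 (0.19 log units; within the scatter), within the scatter.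

Compound 4 `OC[C@H]1O[C@@H](n2cnc3c(NCc4ccc(F)c(Cl)c4)ncnc32)[C@H](O)[C@@H]1O` is not yet measured. It differs from compound 1 in one place: 3-chloro-4-fluorophenyl in place of 3-fluorophenyl on a saturated chain carbon bound to a nitrogen on an aromatic ring. Going by the values given here, no measured pair covers this exact change. What bears on it is that every alteration of the 3-fluorophenyl group seen so far, whether to 2,3,4-trifluorophenyl or to 3,5-dimethoxyphenyl, raised the number in this assay by a large margin. On this basis a higher number for compound 4 is expected, of moderate size, estimated as a 4.3-fold higher number from compound 1 to compound 4 (0.64 log units; beyond the scatter). For compound 4 the value in this assay is estimated at 4000 nM, expected to lie between 1200 nM and 15000 nM.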

Compound 4, half-maximal inhibitory concentration: 3500 nM
Compound 4: the middle estimate sits 1.1-fold (0.06 log units) above what was measured; measured number inside the range.
By their numbers in this assay, from the lowest: compound 1; then compound 4; then compounds 3 and 2 (each within the scatter of the next).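

In this assay the change to 3-chloro-4-fluorophenyl on a saturated chain carbon bound to a nitrogen on an aromatic ring gives a 3.8-fold higher number from compound 1 to compound 4 (0.58 log units; beyond the scatter). This shows that altering the 3-fluorophenyl group need not bring a step as large as those to compounds 2 and 3. Compound 4 also stands apart from both of those compounds, with a 3.7-fold lower number from compound 3 to compound 4 (0.57 log units; beyond the scatter) and a 5.8-fold lower number from compound 2 to compound 4 (0.76 log units; beyond the scatter) placing it at an intermediate level in this small set. Nothing available here accounts for these differences.

Open, as far as these compounds go, is how a 3-chlorophenyl group or a 4-fluorophenyl group alone would compare with compound 1, which would separate the two parts of this change. Also open, from the compounds shown here alone, is how a phenyl group carrying an amine or a carboxylic acid would behave at this place.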